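The compounds below may be only part of what the source reports. "The series", "measured", "known", "first", "only" and "open" are said of these compounds alone.

Compound 1 `O=c1c(C2CC2)cc(-c2ccc(F)nc2F)nn1Cc1ccc(Cl)cc1` is the starting point, and in an ADME assay on HepG2 2.2.15 cells (Homo sapiens) for cytotoxicity, read by MTT assay, with a stated time of 8 days (on this read-out lower numbers stand for higher toxicity in this test and higher numbers for lower toxicity in this test), compound 1 gives 39800 nM. Going by the values given here, that is the only exact number available here. Compound 2 `CNc1ccc(-c2nn(Cc3ccc(C#N)cc3)c(=O)c3ccccc23)c(F)n1`, built differently, reads > 100000 nM, which is a limit of the assay and not a number.

Compound 3 `O=C(O)c1cc(-c2ccc(F)nc2F)nn(Cc2ccc(Cl)cc2)c1=O` has not been measured yet. It keeps the 2,6-difluoropyridin-3-yl group and the 4-chlorobenzyl group of compound 1 and differs in one place: carboxy in place of cyclopropyl on an aromatic carbon. This is carboxy in place of cyclopropyl on an aromatic carbon, opposite the ring nitrogen.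

Among the compounds with values here, no measured pair shows what this swap does, so any forecast is a judgement rather than a reading from data. A modest move towards higher numbers in this assay is expected, which would mean lower toxicity in this test. There is also a real chance that the result comes back only as a limit. The expected change is a 2.0-fold higher number from compound 1 to compound 3 (0.30 log units; within the scatter). For compound 3 the estimate is 80000 nM, with an expected range from 35000 nM to 100000 nM.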

Compound 3, half-maximal cytotoxic concentration: > 100000 nM
Compound 3 ended at the assay's limit; the forecaster's own chance of this, stated with the estimate: 50%; middle value at least 1.2-fold (0.09 log units) away from the limit.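

Going by these compounds alone, this is the first single change that can be read at this position, opposite the ring nitrogen: in this assay, putting carboxy in place of cyclopropyl gives an at least 2.5-fold higher number from compound 1 to compound 3 (0.40 log units; beyond the scatter) and so points to lower toxicity in this test. The number of heavy atoms stays the same in this swap, while a ring of carbon only gives way to an open group with a hydrogen-bond donor and a hydrogen-bond acceptor, so this position responds to what the group is and not only to how many heavy atoms it holds. Compound 3 reads as a limit and not as a number, so the step gives only the smallest possible size of the change and its true size stays unknown: the limit of > 100000 nM in this assay, at which 2 of the 3 values shown sit.

With only one swap at this position, the compounds shown cannot tell whether the rise belongs to carboxy in particular or would also appear with another group here, such as an amine or a methyl ester. Compound 2 differs from compound 1 in more than one place, so it cannot show whether the same swap would have a similar effect on a different core.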